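The source may hold more compounds than are shown below. What is called first, only, known or untested is meant among the compounds shown, and "the series" means these compounds.

Compound 1 `CC(C)(C)NCc1cc(Cl)cc(Nc2nc3cc(F)c(F)cc3n2Cc2ccc(C(F)(F)F)cc2)c1O`: 94%
Compound 2 `CCNCc1cc(C)cc(Nc2nc3ccccc3n2Cc2ccc(C(F)(F)F)cc2)c1O`: 52%

In an ADME assay on microsomes from liver (Mus musculus) for metabolic stability, read by LC-MS, with a stated time of 30 min, tested at 1 uM (a higher number here means that more of the compound is left, a lower number that less of the compound is left), compound 1 stands highest of the two measured compounds at 94%, and compound 2 gives 52%, a gap beyond the usual scatter.

The next compound to be tested is compound 3 `Cc1cc(CNC(C)(C)C)c(O)c(Nc2nc3cc(F)c(F)cc3n2Cc2ccc(C(F)(F)F)cc2)c1`. It keeps the rest of compound 1 but carries methyl in place of chloro on an aromatic carbon. This carbon is para to a hydroxy group and meta to a ((tert-butyl)amino)methyl group.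

Going by the values given here, no measured pair shows this change on its own, so the expectation is only tentative. Compound 1 at 94% leaves little room for a rise, so a small fall is expected, not beyond the scatter. The estimated change is a number 8 percentage points lower from compound 1 to compound 3 (within the scatter). For compound 3 the expected value in this assay is 86%, with an estimated range from 68% to 97%.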

Compound 3, percent of the compound remaining: > 99%
Compound 3: a limit, no number (the forecaster's own chance of this, stated with the estimate: 0%); at least 13 percentage points between middle value and limit.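

In this assay compound 3 gives > 99%, which is a limit of the assay and not a number. On this aromatic carbon, para to a hydroxy group and meta to a ((tert-butyl)amino)methyl group, methyl in place of chloro reads as a number at least 5 percentage points higher from compound 1 to compound 3 (that floor lies within the scatter), so in this setting the high reading does not depend on chloro. Only a floor can be given for this step, because the reading of compound 3 sits at the top of the range: the limit of > 99% in this assay, at which 1 of the 3 values shown sits.

The compounds shown leave open how a methoxy group, a nitrile or a bromine on this carbon would read. Going by these compounds, compound 2 also carries methyl here but differs from compound 3 in more than one place, so whether the change holds alongside other side chains remains unknown.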